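The compounds below may be only part of what the source reports. "The series", "measured", "known", "first", "only" and "open" are said of these compounds alone.

Compound 1 `CN(C)CCCNc1nc(-c2ccc(NC(=O)Nc3ccccc3Cl)cc2)nc2c(Cl)c(Cl)sc12` carries a 2-chlorophenyl on an amide-type nitrogen, and in a functional assay on NCI-H460 cells (Homo sapiens) for cytotoxicity, read by MTT assay, with a stated time of 72 h (a lower number here means a stronger inhibitor, a higher number a weaker inhibitor), compound 1 gives 490 nM. Compound 2 `Cc1ccc(NC(=O)Nc2ccc(-c3nc(NCCCN(C)C)c4sc(Cl)c(Cl)c4n3)cc2)cc1` carries a 4-methylphenyl in that place, and in this assay compound 2 gives 1110 nM. Going by the values given here, the only measured step, a 2.3-fold higher number from compound 1 to compound 2 (0.36 log units; beyond the scatter), comes from that exchange of the aryl group on the amide-type nitrogen. Compound 2 therefore stands with the higher of the two numbers shown, and compound 1 is its only neighbour.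

Compound 3 `CCN(CC)CCCNc1nc(-c2ccc(NC(=O)Nc3ccc(C)cc3)cc2)nc2c(Cl)c(Cl)sc12` differs from compound 2 in one place: diethylamino in place of dimethylamino on a saturated chain carbon, three bonds along the chain from a nitrogen on an aromatic ring. Among the compounds with values here, no measured step touches the group on that saturated chain carbon; the one step known, which concerns the aryl group, says nothing about it. With nothing to point in either direction, compound 3 is expected to give a number close to that of compound 2 in this assay, the expected step of a 1.0-fold lower number from compound 2 to compound 3 (0.00 log units; within the scatter) lying within the scatter. Compound 3 is estimated at 1100 nM, with a range from 400 nM to 3000 nM.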

Compound 3, half-maximal inhibitory concentration: 1240 nM
The estimate for compound 3 lay 1.1-fold (0.05 log units) below the measured number, within the range that was stated.
By their numbers in this assay, from the lowest: compound 1; then compounds 2 and 3 (each within the scatter of the next).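

In this assay, the exchange of dimethylamino for diethylamino on a saturated chain carbon, three bonds along the chain from a nitrogen on an aromatic ring, gives a 1.1-fold higher number from compound 2 to compound 3 (0.05 log units; within the scatter). Going by these compounds alone, the earlier step concerned only the aryl group on the amide-type nitrogen, so this is the first reading at this position, and it shows that, with 4-methylphenyl on that nitrogen, the two amines cannot be told apart in this assay. Nothing available here bears on this result or offers a reason for it.

On these data alone, this rests on a single pair, so it remains open whether diethylamino and dimethylamino would also read alike with 2-chlorophenyl on the amide-type nitrogen. Also open, as far as these compounds go, is how the number would respond to a more different group at this position, such as a pyrrolidine or morpholine ring, a primary amine or a hydroxyl group, or to a shorter or longer chain than the 3-(dimethylamino)propyl and 3-(diethylamino)propyl chains compared here.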